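A few compounds are considered here, and "the series" means these few. Any claim that something is new, unique, unknown or untested is made for them only; others in the source may bear on it.

Measured compounds:
compound 1, `CCCOC(=O)C1=C(C)NC(=O)NC1c1cccs1`, 43%;
compound 2, `CC1=C(C(=O)OCC(C)C)C(c2cccs2)NC(=O)N1`, 25%;
compound 3, `CCCOC(=O)C1=C(C)N(C)C(=O)NC1c1ccco1`, 3%.

All three were examined in an assay on membranes from CHO cells for displacement of a labelled ligand from adenosine receptor A1 (Homo sapiens), read by scintillation counting, with a stated time of 60 min, tested at 1 uM; a higher number here means more inhibition at the concentration tested (going by the name of the read-out), a lower number less inhibition. Compound 1 gives 43%, and compound 2 gives 25%. Between them stands one change, (methyl in place of hydrogen on a saturated chain carbon bound to two saturated chain carbons), and the step it made was a number 18 percentage points lower from compound 1 to compound 2 (beyond the scatter). Compound 3 gives 3%, the lowest of the three numbers; its gap to compound 2 and its gap to compound 1 both lie beyond the scatter. The difference between the core of compound 1 and the core of compound 3 is not broken down here.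

Compound 4, `CC1=C(C(=O)OCC(C)C)C(c2ccco2)NC(=O)N1C`, has not been measured. It differs from compound 3 by methyl in place of hydrogen on a saturated chain carbon bound to two saturated chain carbons, the same change that separates compound 1 from compound 2, and it occurs twice among the compounds shown. Since compound 3 already stands near the bottom of the read-out, little room is left for a downward step of the earlier size. The expected step is therefore a number 3 percentage points lower from compound 3 to compound 4 (within the scatter), resting on compound 1 and compound 2 because that pair gave a number 18 percentage points lower from compound 1 to compound 2 (beyond the scatter) and on compound 3 because its own number is 3%. Compound 4 is thus estimated at 0%, with the range from -12% to 12%.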

Compound 4, a percentage reported as inhibition, at one concentration (the size of the read-out at that concentration, not a potency): 13%
Compound 4: middle estimate off by 13 percentage points, on the low side, and the stated range ends below it.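

In this assay, the change from propoxy to isobutoxy on the core of compound 3 gave a number 10 percentage points higher from compound 3 to compound 4 (within the scatter), so on this core the two compounds cannot be told apart. Set beside the same change on the core of compound 1, the result shows that in this series the step seen on one core does not carry over as a fixed step to the other: the same change on two cores in this assay, a number 18 percentage points lower (beyond the scatter) from compound 1 to compound 2 and a number 10 percentage points higher (within the scatter) from compound 3 to compound 4, 28 percentage points apart, beyond the scatter of two such steps

This does not show which of the differences between the two cores lies behind the contrast, and two pairs give no rule for any further core; the read-out also gives the size of inhibition at a single concentration, not a potency, so neither step says how far the change moves potency.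

The compounds shown carry only propoxy and isobutoxy in this place, so it remains open how a longer chain, such as butoxy, or a chain ending in an amine or a carboxylic acid, would behave on either core. For the compounds shown here, they also include no pair that separates the differences between the core of compound 1 and the core of compound 3, so the part each difference plays stays unresolved.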